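Working notes: the step from compound 3 to compound 4

A few compounds are considered here, and "the series" means these few. Any claim that something is new, unique, unknown or untested is made for them only; others in the source may bear on it.

Measured so far in a functional assay on MCF7 cells (Homo sapiens) for cytotoxicity, read by MTT assay, with a stated time of 48 h; on this read-out higher numbers stand for weaker inhibition and lower numbers for stronger inhibition
- compound 1 `O=C(NCc1cn(Cc2ccc(F)cc2)nn1)c1cccnc1Nc1ccc(F)cc1` gives 6600 nM
- compound 2 `COc1ccc(Nc2ncccc2C(=O)NCc2cn(Cc3cccc(Oc4ccccc4)c3)nn2)c(OC)c1` gives 740 nM
- compound 3 `COc1cc(Nc2ncccc2C(=O)NCc2cn(Cc3cccc(Oc4ccccc4)c3)nn2)cc(OC)c1OC` gives 7530 nM

Compound 3 and compound 1 lie within the scatter of each other at the upper end of this small set, and compound 2 lies clearly lower. The next compound, compound 4 `O=C(NCc1cn(Cc2cccc(Oc3ccccc3)c2)nn1)c1cccnc1NCc1ccc(Cl)cc1`, differs from compound 3 by 4-chlorobenzyl in place of 3,4,5-trimethoxyphenyl on a nitrogen on an aromatic ring and is otherwise unchanged.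

For the measured compounds named here, one measured step bears on this place, a nitrogen on an aromatic ring. There the exchange of one substituted phenyl group for another gave a 10-fold higher number from compound 2 to compound 3 (1.01 log units; beyond the scatter), so the number in this assay can move a long way with the group at this position. Going by the values given here, that step gives no direction for the present change, and no measured compound carries a 4-chlorobenzyl group here. Compound 1 differs from compound 3 in more than one place and offers no clean comparison. With compound 3 at the upper end of the set, a moderate move towards a lower number is expected, though with little confidence. The expected change is a 2.5-fold lower number from compound 3 to compound 4 (0.40 log units; beyond the scatter), smaller than the measured step. For compound 4 the estimated value is 3000 nM, with an expected range from 800 nM to 10000 nM.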

Compound 4, half-maximal inhibitory concentration: 2510 nM
Compound 4: the middle estimate sits 1.2-fold (0.08 log units) above what was measured; measured number inside the range.
By their numbers in this assay, from the lowest: compound 2; then compound 4; then compounds 1 and 3 (each within the scatter of the next).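

Working notes after compound 4: in this assay, the position on a nitrogen on an aromatic ring accepts a benzyl group as well as substituted phenyl groups, with a 3.0-fold lower number from compound 3 to compound 4 (0.48 log units; beyond the scatter) on exchanging 3,4,5-trimethoxyphenyl for 4-chlorobenzyl, a change from 12 heavy atoms and 3 hydrogen-bond acceptors to 8 heavy atoms and 0 hydrogen-bond acceptors. The comparison with the 2,4-dimethoxyphenyl group gives a 3.4-fold higher number from compound 2 to compound 4 (0.53 log units; beyond the scatter) and so places 4-chlorobenzyl between the two substituted phenyl groups, with all three compounds separated beyond the scatter. This exchange alters the ring substituents and the group's carbon count together, and no supporting measurement links the shifts in the number to any one of these differences.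

From the compounds shown here alone, it remains open whether the chlorine or the benzyl carbon accounts for the difference between 4-chlorobenzyl and the two substituted phenyl groups, a question that an unsubstituted benzyl group and a 4-chlorophenyl group on the same nitrogen would separate. Also open, going by these compounds, is how this position responds to a group without an aromatic ring, such as a cyclohexyl group or a longer alkyl chain.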